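Adding a Second Chloro to a Phenoxy-Type Agonist

This account rests on a few compounds, and the source may have more. Where it says the series, first, only, none or still open, it means among the compounds named here.

The measured compounds:
Compound 1, `O=C1NC(=O)C(Cc2ccc(Oc3ncc(C(F)(F)F)cc3Cl)cc2Cl)S1`: 26 nM
Compound 2, `O=C1NC(=O)C(Cc2ccc(Oc3cccc(Cl)c3)cc2)S1`: 318 nM
Compound 3, `O=C1NC(=O)C(Cc2ccc(Oc3ncc(C(F)(F)F)cc3Cl)cc2)S1`: 69 nM

The three compounds share the same core and were tested in a functional assay for agonist activity at Free fatty acid receptor 1 (Homo sapiens), read by FLIPR, in the presence of a further agent that is not named here; a lower number here means that less compound is needed, a higher number that more compound is needed for the effect. Compound 2 gives the highest number of the three. The difference between the cores of compound 2 and compound 3 is not broken down here. From compound 3 to compound 1 the change is chloro in place of hydrogen on an aromatic carbon, and it gave a 2.7-fold lower number from compound 3 to compound 1 (0.42 log units; beyond the scatter).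

Compound 4, `O=C1NC(=O)C(Cc2ccc(Oc3cc(Cl)cc(Cl)c3)cc2)S1`, has not yet been measured. It differs from compound 2 by chloro in place of hydrogen on an aromatic carbon. This is the same kind of change as that from compound 3 to compound 1, but not the same: there the chloro enters ortho to a (2,4-dioxo-1,3-thiazolidin-5-yl)methyl group, here it enters meta to a chloro group. Resting on the step from compound 3 to compound 1, compound 4 is expected to give a step of a 2.0-fold lower number from compound 2 to compound 4 (0.30 log units; within the scatter), smaller since the place differs. Compound 4 is therefore estimated at 160 nM, within 60 nM to 420 nM.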

Compound 4, half-maximal effective concentration: 207 nM
Compound 4: middle estimate off by 1.3-fold (0.11 log units), on the low side; low and high end bracket the measured number.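

In this assay, the added chloro gave a 1.5-fold lower number from compound 2 to compound 4 (0.19 log units; within the scatter). Set beside the earlier case, the two steps cannot be told apart: the same change on two cores in this assay, a 2.7-fold lower number (0.42 log units; beyond the scatter) from compound 3 to compound 1 and a 1.5-fold lower number (0.19 log units; within the scatter) from compound 2 to compound 4, 1.7-fold (0.24 log units) apart, within the scatter of two such steps. Among the compounds shown here, this shows that the change kept its direction and no measurable difference in size on the second core, but it does not show a general rule, since only two cores are compared, the chloro enters at a different place on each, and the newer step does not itself stand clear of the scatter.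

The compounds shown leave open whether a fluoro, methyl or methoxy in place of this chloro would give a step of another size. They also leave open whether the step would hold on a core carrying a carboxylic acid.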